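The source may report more compounds than this note shows. Statements on the series, on what has been measured and on what is new or still open speak of the compounds shown alone.

Measured compounds:
compound 1 `CCN1CCc2nc(C#Cc3ccccc3)sc2C1` — 1200 nM
compound 2 `C(#Cc1nc2c(s1)CN(C1CCCCC1)CC2)c1ccccc1` — > 10000 nM

In an assay on HEK293 cells for negative allosteric modulation of metabotropic glutamate receptor 5 (Homo sapiens), read by FLIPR, with a stated time of 1 h (a higher number here means a weaker inhibitor, a lower number a stronger inhibitor), compound 1 gives 1200 nM. For compound 2 the assay reports only a limit, > 10000 nM. Compound 2 therefore sits at the limit of > 10000 nM in this assay, at which 1 of the 2 values shown sits, and only a limit is known for it. Going by the values given here, the one measured step, an at least 8.3-fold higher number from compound 1 to compound 2 (0.92 log units; beyond the scatter), went toward weaker inhibition.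

Compound 3 `CC(=O)N1CCc2nc(C#Cc3ccccc3)sc2C1` differs from compound 2 by acetyl in place of cyclohexyl on an amine nitrogen in a ring. Only the step from compound 1 to compound 2 bears on this change, and it concerned the same nitrogen; whether removing cyclohexyl recovers the loss when acetyl rather than ethyl enters is not shown by these two compounds. Compound 3 is expected near 5000 nM, within 1000 nM to 15000 nM, which is estimated as an at least 2.0-fold lower number from compound 2 to compound 3 (0.30 log units; that floor lies within the scatter).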

Compound 3, half-maximal inhibitory concentration: 90 nM
Estimate against measurement, compound 3: 56-fold (1.74 log units) above; measured number outside the range, below it.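

Going by these compounds alone, until now the only change on this amine nitrogen in a ring weakened inhibition; acetyl in place of ethyl gives a 13-fold lower number from compound 1 to compound 3 (1.12 log units; beyond the scatter), so substitution here can also strengthen it. Acetyl in place of cyclohexyl gives an at least 110-fold lower number from compound 2 to compound 3 (2.04 log units; beyond the scatter). That step is only a floor, as compound 2 carries a limit: the limit of > 10000 nM in this assay, at which 1 of the 3 values shown sits.

Going by these compounds, whether the gain depends on the carbonyl or on acetyl as a whole remains open. A propanoyl, methyl carbamate or methanesulfonyl group on the same nitrogen would address this.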